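Swapping a pyrimidinone arm for diisopropylamino on a nucleoside core

This account rests on a few compounds, and the source may have more. Where it says the series, first, only, none or still open, it means among the compounds named here.

Compound 1 `O=c1ccn(Cc2ncnc3c2ncn3[C@@H]2O[C@H](CO)[C@@H](O)[C@H]2O)cc1` was tested in a functional assay on Huh-7 cells (Homo sapiens) for cytotoxicity, read by MTT assay, with a stated time of 3 days; a higher number here means that more compound is tolerated, a lower number that less compound is tolerated. Compound 1 gives only a limit there, > 100000 nM. Compound 2 `CC(=O)N(Cc1ncnc2c1ncn2[C@@H]1O[C@H](CO)[C@@H](O)[C@H]1O)C1CCCCC1` likewise gives only a limit, > 100000 nM. Within the data shown here, both sit at the limit of > 100000 nM in this assay, at which 2 of the 2 values shown sit, so no measured step in this assay is known. Compound 3 `CC(C)N(Cc1ncnc2c1ncn2[C@@H]1O[C@H](CO)[C@@H](O)[C@H]1O)C(C)C` differs from compound 1 by a group of 7 heavy atoms (6 carbon, 1 nitrogen; no ring) in place of a group of 7 heavy atoms (5 carbon, 1 nitrogen, 1 oxygen; one six-membered aromatic ring with 1 hetero atom), on a saturated chain carbon bound to an aromatic carbon. With the two neighbours both at the limit, the expected step of a number no higher from compound 1 to compound 3 (the limit leaves the size open) is none beyond the scatter. Compound 3 is therefore expected to give about 100000 nM in this assay, within 30000 nM to 300000 nM, most likely again reported as a limit.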

Compound 3, half-maximal cytotoxic concentration: 18000 nM
Beside the measured number, compound 3's estimate is 5.6-fold (0.74 log units) above it; the measured number lies below the stated range.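

Putting diisopropylamino in place of the ring-bearing group of compound 1, on a saturated chain carbon bound to an aromatic carbon, gives an at least 5.5-fold lower number from compound 1 to compound 3 (0.74 log units; beyond the scatter) in this assay. This is the first sign that the group at this place can bring cytotoxicity on these cells into the measurable range, which the earlier compounds could not show: the limit of > 100000 nM in this assay, at which 2 of the 3 values shown sit.

On these data alone, the full size of the step stays unknown, as the value for compound 1 is only a limit. As far as these compounds go, whether a smaller dimethylamino or a carboxylic acid at this place would lower the number too remains open.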